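Dropping the trifluoromethoxy group from compound 2

The source may hold more compounds than are shown below. What is called first, only, known or untested is meant among the compounds shown, and "the series" means these compounds.

Measured in an ADME assay on THP-1 cells (Homo sapiens) for cytotoxicity; on this read-out lower numbers stand for higher toxicity in this test and higher numbers for lower toxicity in this test:
compound 1 `COc1ccc(CNC(=O)c2c(NC(=O)C(F)(F)F)sc3c2CCCCC3)cc1`: > 50000 nM (a limit of the assay, not a number)
compound 2 `O=C(Nc1ccc(OC(F)(F)F)cc1)c1c(NC(=O)C(F)(F)F)sc2c1CCCCC2`: 11900 nM

For the measured compounds named here, compound 2 holds the only true number in this small set, at 11900 nM. Compound 1 gives > 50000 nM, which is a limit of the assay.

The next compound to be tested is compound 3 `O=C(Nc1ccccc1)c1c(NC(=O)C(F)(F)F)sc2c1CCCCC2`. It keeps the core of compound 2 and changes in one place: hydrogen in place of trifluoromethoxy on an aromatic carbon. In short, hydrogen stands in place of trifluoromethoxy on an aromatic carbon, para to a large group.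

Going by the values given here, no two measured compounds differ in one place only, so this assay offers no direct guide to this change. A modest shift towards higher numbers, meaning lower toxicity in this test, is expected rather than a fall. That lean rests only on compound 1, with the limit of > 50000 nM in this assay, at which 1 of the 2 values shown sits. The expected change is a 2.0-fold higher number from compound 2 to compound 3 (0.30 log units; within the scatter), and it is a modest one. For compound 3 the estimated value is 24000 nM, within an expected range from 10000 nM to 50000 nM.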

Compound 3, half-maximal cytotoxic concentration: > 50000 nM
Compound 3 gave a limit, no number; the forecaster's own chance of this, stated with the estimate: 35%; middle value at least 2.0-fold (0.31 log units) from the limit.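

In this assay, hydrogen in place of trifluoromethoxy on an aromatic carbon, para to a large group, gives an at least 4.2-fold higher number from compound 2 to compound 3 (0.62 log units; beyond the scatter). For the compounds shown here, this is the first comparison in which only this one place changes, and it shows that this place matters for the read-out: the step lies beyond the usual scatter and runs towards lower toxicity in this test. The step gives only a lower bound on the change and not its full size, because compound 3 stops at a limit of the assay, as one other compound shown does: the limit of > 50000 nM in this assay, at which 2 of the 3 values shown sit.

The step between compound 1 and compound 3 cannot be read, as both values are limits. From the compounds shown here alone, it also remains open whether the lower number of compound 2 is particular to trifluoromethoxy, or whether another group on the same aromatic carbon, such as a chlorine atom, an amine or a carboxylic acid, would also bring the number down into the measurable range.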